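Amide chain variation across two cores of one series

The compounds below may be only part of what the source reports. "The series", "measured", "known", "first", "only" and "open" are said of these compounds alone.

Compound 1 `CC(C)=CC(=O)Nc1cccc(Oc2nc(Nc3ccn(C)n3)nc3c2CSCC3)c1` and compound 2 `CC(C)/C=C/C(=O)Nc1cccc(Oc2nc(Nc3ccn(C)n3)nc3c2CSCC3)c1` share a core and differ only in the group on the amide carbonyl. In a functional assay on A549 cells (Homo sapiens) for antiproliferative activity, read by MTT assay, with a stated time of 72 h (a higher number here means a weaker inhibitor, a lower number a stronger inhibitor), compound 1 gives 44200 nM and compound 2 gives 33500 nM; the change 3-methylbut-1-en-1-yl in place of 2-methylprop-1-en-1-yl on a carbonyl carbon made a step of a 1.3-fold lower number from compound 1 to compound 2 (0.12 log units; within the scatter). Compound 3 `CC(C)=CC(=O)Nc1cccc(Oc2nc(Nc3cccc(C#N)c3)nc3c2CSCC3)c1` carries another group on the core, the difference being (3-cyanophenyl in place of 1-methyl-1H-pyrazol-3-yl on a nitrogen on an aromatic ring); in this assay compound 3 gives 36900 nM, a step of a 1.2-fold lower number from compound 1 to compound 3 (0.08 log units; within the scatter). All three values lie within the scatter of one another, so no order among compound 1, compound 2 and compound 3 can be read from them.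

Compound 4 `CC(C)/C=C/C(=O)Nc1cccc(Oc2nc(Nc3cccc(C#N)c3)nc3c2CSCC3)c1` is not yet measured. It stands to compound 3 as compound 2 stands to compound 1: the change is 3-methylbut-1-en-1-yl in place of 2-methylprop-1-en-1-yl on a carbonyl carbon, the same change as in the measured pair, at the same place, a carbonyl carbon whose other neighbour is an amide-type nitrogen. The change appears in two pairs among these compounds, only one of them measured. Whether the effect carries over to the core of compound 3 is not shown by the data.

The step from compound 3 to compound 4 in this assay is expected to be a 1.3-fold lower number from compound 3 to compound 4 (0.10 log units; within the scatter), because the measured step of a 1.3-fold lower number from compound 1 to compound 2 (0.12 log units; within the scatter) stayed within the scatter. For compound 4 the estimate in this assay is 29000 nM, with a range from 15000 nM to 60000 nM.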

Compound 4, half-maximal inhibitory concentration: 35900 nM
For compound 4 the middle estimate is 1.2-fold (0.09 log units) below the measured one; the range from low to high includes it.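

In this assay the amide chain change on the second core gives a 1.0-fold lower number from compound 3 to compound 4 (0.01 log units; within the scatter), and this step does not differ from the one on the first core by more than the scatter: the same change on two cores in this assay, a 1.3-fold lower number (0.12 log units; within the scatter) from compound 1 to compound 2 and a 1.0-fold lower number (0.01 log units; within the scatter) from compound 3 to compound 4, 1.3-fold (0.11 log units) apart, within the scatter of two such steps. The exchange of 1-methyl-1H-pyrazol-3-yl for 3-cyanophenyl, read with 3-methylbut-1-en-1-yl on the carbonyl carbon, gives a 1.1-fold higher number from compound 2 to compound 4 (0.03 log units; within the scatter), and this step likewise stays close to its earlier counterpart: the same change on two cores in this assay, a 1.2-fold lower number (0.08 log units; within the scatter) from compound 1 to compound 3 and a 1.1-fold higher number (0.03 log units; within the scatter) from compound 2 to compound 4, 1.3-fold (0.11 log units) apart, within the scatter of two such steps. Among these compounds, both changes therefore leave the number within the scatter on either core, but since no step here goes beyond the scatter, this shows only that no effect appears in these four compounds, not that a real effect of a change would carry from one core to the other.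

The compounds shown carry only 2-methylprop-1-en-1-yl and 3-methylbut-1-en-1-yl on the carbonyl carbon, and only 1-methyl-1H-pyrazol-3-yl and 3-cyanophenyl on the nitrogen on the aromatic ring. On these data alone, whether a saturated chain, a longer chain, or a chain ending in an amine or a carboxylic acid would move the number in this assay beyond the scatter, and whether such a step would then hold on both cores, remains open.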